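The source may report more compounds than this note shows. Statements on the series, on what has been measured and on what is new or still open speak of the compounds shown alone.

Of the compounds shown here, two measured so far share one core. Compound 1 `CC1CCN(C2CCN(S(=O)(=O)c3cccnc3)CC2)CC1` gives 2400 nM in a functional assay on DLD-1 cells (Homo sapiens) for antiproliferative activity, read by CellTiter-Glo, with a stated time of 72 h; on this read-out higher numbers stand for weaker inhibition and lower numbers for stronger inhibition. Compound 2 `Cc1cccc(S(=O)(=O)N2CCC(N3CCC(C)CC3)CC2)c1` gives 25 nM in this assay, and it stands as the lowest of the two numbers; the step of a 96-fold lower number from compound 1 to compound 2 (1.98 log units; beyond the scatter) came with a 3-methylphenyl in place of a pyridin-3-yl on the sulfonyl sulfur. Compound 3 `Cc1ccc(C#N)c(S(=O)(=O)N2CCC(N3CCC(C)CC3)CC2)c1` carries a cyano in place of hydrogen on an aromatic carbon, ortho to a large group and para to a methyl group (cyano in place of hydrogen on an aromatic carbon). For the measured compounds named here, no measured step touches this ring position: the one step known concerns a swap of the whole ring, so it does not tell what a cyano added to it does. The expected step is therefore small, a 1.6-fold higher number from compound 2 to compound 3 (0.20 log units; within the scatter), with the direction left open. Compound 3 is estimated at 40 nM, between 10 nM and 200 nM.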

Compound 3, half-maximal inhibitory concentration: 285 nM
Compound 3: the middle estimate sits 7.1-fold (0.85 log units) below what was measured; measured number outside the range, above it.
By their numbers in this assay, from the lowest: compound 2; then compound 3; then compound 1.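

For the compounds shown here, this is the first change made on the 3-methylphenyl ring itself rather than a swap of the whole ring, and it shows that this position matters. In this assay a cyano, ortho to a large group and para to a methyl group, comes with an 11-fold higher number from compound 2 to compound 3 (1.06 log units; beyond the scatter) and so weakens inhibition clearly, even though it adds only 2 heavy atoms. Nothing at hand gives a reason for this loss.

With only hydrogen and cyano shown at this position, it remains open whether the loss is specific to the cyano or would follow from any group placed there. A fluorine atom, a methoxy group or an amine at the same position would help separate these two readings.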